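Orexin-2 antagonists: aryl swap on the amide nitrogen

The compounds below may be only part of what the source reports. "The series", "measured", "known", "first", "only" and "open" are said of these compounds alone.

Measured so far:
- compound 1 `Cc1cccc(NC(=O)CSc2nnc(-c3ccoc3C)n2Cc2ccco2)c1C`: > 15800 nM
- compound 2 `Cc1occc1-c1nnc(SCC(=O)Nc2ccc(F)c(Cl)c2)n1Cc1ccco1`: 39.8 nM

In a functional assay on CHO cells for antagonist activity at Orexin receptor type 2 (Homo sapiens), read by FLIPR and calcium flux (on this read-out higher numbers stand for weaker inhibition and lower numbers for stronger inhibition), compound 1 gives only a limit, > 15800 nM. Within the data shown here, compound 2 gives 39.8 nM, the only real number in this assay so far. Among the measured compounds shown here, the one measured step, an at least 390-fold lower number from compound 1 to compound 2 (2.59 log units; beyond the scatter), shows that the aryl group on the amide-type nitrogen moves the read-out strongly, with compound 1 sitting at the limit (the limit of > 15800 nM in this assay, at which 1 of the 2 values shown sits).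

Compound 3 `Cc1occc1-c1nnc(SCC(=O)Nc2ccc(N(C)C)cc2)n1Cc1ccco1` differs from compound 2 by 4-(dimethylamino)phenyl in place of 3-chloro-4-fluorophenyl on an amide-type nitrogen. For the measured compounds named here, since the only step shows that aryl changes here are large, a sizeable shift toward weaker inhibition is expected, with a real chance of another limit. Compound 3 is estimated at 800 nM (range 80 nM to 8000 nM), a step of a 20-fold higher number from compound 2 to compound 3 (1.30 log units; beyond the scatter) expected.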

Compound 3, inhibition constant: 158 nM
For compound 3 the middle estimate is 5.1-fold (0.70 log units) above the measured one; the range from low to high includes it.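

In this assay the aryl group on the amide-type nitrogen is not all-or-nothing: 4-(dimethylamino)phenyl keeps a real number, with a modest penalty against 3-chloro-4-fluorophenyl (a 4.0-fold higher number from compound 2 to compound 3 (0.60 log units; beyond the scatter)). Replacing 2,3-dimethylphenyl with 4-(dimethylamino)phenyl gives a much larger change (an at least 100-fold lower number from compound 1 to compound 3 (2.00 log units; beyond the scatter)). Compound 1 is a limit, so that step is only a bound: the limit of > 15800 nM in this assay, at which 1 of the 3 values shown sits.

Still open, as far as these compounds go, is whether the loss in compound 1 belongs to the 2,3-dimethylphenyl pattern as a whole or to one of its methyl groups. Also open, from the compounds shown here alone, is how a primary amine or a carboxylic acid would read in place of the dimethylamino group.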